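Swapping a Difluorophenyl for a Chloropropyl Chain

This account rests on a few compounds, and the source may have more. Where it says the series, first, only, none or still open, it means among the compounds named here.

The account follows compound 1, `O=C1O[C@H]([C@@H](O)Cn2cc(-c3cc(F)cc(F)c3)nn2)C(OCc2ccccc2)=C1OCc1ccccc1`, a hydroxy-bearing member of this series. Going by the values given here, in a functional assay on CFPAC-1 cells (Homo sapiens) for antiproliferative activity, read by MTT assay, with a stated time of 72 h (a higher number here means a weaker inhibitor, a lower number a stronger inhibitor), compound 1 gives 62400 nM, the only number recorded among the three measured compounds. Compound 2, `O=C1O/C(=C\Cn2cc(-c3ccc(Br)cc3)nn2)C(OCc2ccccc2)=C1OCc1ccccc1`, reaches only a limit of the assay in this assay, > 100000 nM. Compound 3, `COc1ccccc1-c1cn(C/C=C2\OC(=O)C(OCc3ccccc3)=C2OCc2ccccc2)nn1`, likewise sits at a limit in this assay, > 100000 nM. Among the compounds with values here, the single step between measured compounds, a step that the two limits leave unreadable from compound 2 to compound 3, therefore cannot be read, because both ends rest at the limit of > 100000 nM in this assay, at which 2 of the 3 values shown sit. Compound 4, `O=C1O[C@H]([C@@H](O)Cn2cc(CCCCl)nn2)C(OCc2ccccc2)=C1OCc1ccccc1`, differs from compound 1 by 3-chloropropyl in place of 3,5-difluorophenyl on an aromatic carbon. Within the data shown here, no measured step touches this change, and the one recorded step gives no size to lean on, so the expectation rests on compound 1 alone. Compound 4 is expected to stay close to compound 1, with the estimated step of a 1.1-fold higher number from compound 1 to compound 4 (0.05 log units; within the scatter) lying within the scatter. The estimate for compound 4 in this assay is 70000 nM, with a range from 25000 nM to 200000 nM.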

Compound 4, half-maximal inhibitory concentration: 58800 nM
Compound 4: middle estimate off by 1.2-fold (0.08 log units), on the high side, within the range that was stated.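

Putting 3-chloropropyl in place of 3,5-difluorophenyl on this aromatic carbon of the five-membered aromatic ring gives a 1.1-fold lower number from compound 1 to compound 4 (0.03 log units; within the scatter) in this assay, and this is the only readable step among the compounds shown. For this pair, then, the number does not depend on keeping the six-membered aromatic ring at this position, as a chain with no ring and 4 heavy atoms in place of 8 reads the same within the scatter. Nothing measured here gives a reason why the two groups read alike.

The compounds shown leave open how a plain propyl chain, a longer chain, or a chain ending in an amine or a carboxylic acid would read at this position. From the compounds shown here alone, it also remains open whether any group here could bring the number well below that of compound 1 62400 nM.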